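Trimming the benzyloxy group of compound 3 back to methoxy

The source may hold more compounds than are shown below. What is called first, only, known or untested is meant among the compounds shown, and "the series" means these compounds.

compound 1 `C=CCOc1ccc2c(=O)c(-c3cc(OC)c(OC)cc3OC)coc2c1`: 6600 nM
compound 2 `C#CCOc1ccc2c(=O)c(-c3cc(OC)c(OC)cc3OC)coc2c1`: 8050 nM
compound 3 `COc1cc(OC)c(-c2coc3cc(OCc4ccccc4)ccc3c2=O)cc1OC`: 2280 nM

Among the three measured compounds, compound 3 gives the lowest number in a functional assay on HCT-116 cells (Homo sapiens) for antiproliferative activity, read by MTT assay, with a stated time of 24 h; a lower number here means a stronger inhibitor, a higher number a weaker inhibitor: there is a 2.9-fold lower number from compound 1 to compound 3 (0.46 log units; beyond the scatter) and a 3.5-fold lower number from compound 2 to compound 3 (0.55 log units; beyond the scatter), whereas a 1.2-fold higher number from compound 1 to compound 2 (0.09 log units; within the scatter). Compound 4 `COc1ccc2c(=O)c(-c3cc(OC)c(OC)cc3OC)coc2c1` differs from compound 3 by hydrogen in place of phenyl on a saturated chain carbon bound to an oxygen on an aromatic ring. Going by the values given here, no measured step removes the phenyl outright; the two steps that bear on the change both introduced a phenyl and gave modest drops, so taking it away is expected to undo those gains. Since compound 1 gives 6600 nM with only vinyl on that carbon, a still smaller substituent is expected to land near or above it. The estimate for compound 4 is 8000 nM, ranging from 3000 nM to 20000 nM, which is an expected 3.5-fold higher number from compound 3 to compound 4 (0.55 log units; beyond the scatter).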

Compound 4, half-maximal inhibitory concentration: 9170 nM
The estimate for compound 4 lay 1.1-fold (0.06 log units) below the measured number; measured number inside the range.
By their numbers in this assay, from the lowest: compound 3; then compounds 1, 2 and 4 (each within the scatter of the next).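

In this assay, going by these compounds alone, going from benzyloxy to methoxy gives a 4.0-fold higher number from compound 3 to compound 4 (0.60 log units; beyond the scatter) and is the first direct reading of losing the phenyl. Hydrogen, vinyl and ethynyl on that carbon do not separate, with a 1.4-fold higher number from compound 1 to compound 4 (0.14 log units; within the scatter) and a 1.1-fold higher number from compound 2 to compound 4 (0.06 log units; within the scatter) both within the scatter, so among these compounds only the phenyl sets its compound apart. Nothing available explains this difference.

On these data alone, whether the gain needs an aromatic ring at all stays open, since a cyclohexyl group could test that. So does the effect of a longer chain or an amine on that carbon.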